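Tert-butyl for trifluoromethyl on two cores

This account rests on a few compounds, and the source may have more. Where it says the series, first, only, none or still open, it means among the compounds named here.

Measured so far in an assay on CHO-K1 cells for antagonist activity at transient receptor potential cation channel subfamily V member 1 (Homo sapiens), read by FLIPR; on this read-out higher numbers stand for weaker inhibition and lower numbers for stronger inhibition:
compound 1, `CC1CCN(c2nc(C(F)(F)F)ccc2CNC(=O)C(C)c2ccc3c(c2)CCC3)CC1`: 57.4 nM
compound 2, `CC1CCN(c2nc(C(C)(C)C)ccc2CNC(=O)C(C)c2ccc3c(c2)CCC3)CC1`: 44 nM
compound 3, `CC(C(=O)NCc1cc(C(F)(F)F)nn1-c1ccc(C(F)(F)F)cc1)c1ccc2c(c1)CCC2`: 51.3 nM

Compound 1 and compound 2 share one core and differ in a single place: tert-butyl in place of trifluoromethyl on an aromatic carbon. The step of a 1.3-fold lower number from compound 1 to compound 2 (0.12 log units; within the scatter). Compound 3 sits on another core; the difference between the core of compound 1 and the core of compound 3 is not broken down here. Compound 3 and compound 1 give numbers within the scatter of each other, as do compound 3 and compound 2, so the three measured values do not separate.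

Compound 4, `CC(C(=O)NCc1cc(C(C)(C)C)nn1-c1ccc(C(F)(F)F)cc1)c1ccc2c(c1)CCC2`, is not yet measured in this assay. It differs from compound 3 in a single place: tert-butyl in place of trifluoromethyl on an aromatic carbon. Among the measured compounds shown here, this is the same kind of change as the one from compound 1 to compound 2, but the surroundings are not the same: in compound 1 the group sits on an aromatic carbon of a six-membered aromatic ring with 1 nitrogen, next to the ring nitrogen, meta to a 4-methylpiperidin-1-yl group and para to a large group, whereas in compound 3 it sits on an aromatic carbon of a five-membered aromatic ring with 2 nitrogen, next to the ring nitrogen, two ring bonds from the ring atom that bears a 4-(trifluoromethyl)phenyl group and two ring bonds from the ring atom that bears a large group.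

For the measured compounds named here, for compound 4 the expected step is a 1.2-fold lower number from compound 3 to compound 4 (0.09 log units; within the scatter), set beside the one measured instance of this change, a 1.3-fold lower number from compound 1 to compound 2 (0.12 log units; within the scatter), which stayed within the scatter. With a single prior instance on a different core, the expectation is kept wide. Compound 4 is estimated at 42 nM in this assay, with a range from 18 nM to 100 nM.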

Compound 4, inhibition constant: 62.4 nM
Compound 4: middle estimate off by 1.5-fold (0.17 log units), on the low side; measured number inside the range.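

In this assay, tert-butyl in place of trifluoromethyl on an aromatic carbon of the five-membered aromatic ring with 2 nitrogen gives a 1.2-fold higher number from compound 3 to compound 4 (0.09 log units; within the scatter). Set beside the earlier instance of this change, the two steps do not separate, so in this series the swap carries from one core to the other without a detectable difference: the same change on two cores in this assay, a 1.3-fold lower number (0.12 log units; within the scatter) from compound 1 to compound 2 and a 1.2-fold higher number (0.09 log units; within the scatter) from compound 3 to compound 4, 1.6-fold (0.20 log units) apart, within the scatter of two such steps

This shows only that neither of the two cores gives a step beyond the scatter; it assigns no direction to the change, and two small steps in a single assay do not establish that the two groups are interchangeable on any further core in the series.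

Still open, on these data alone, is whether a group of a different kind on the same aromatic carbon, such as a primary amine, a carboxylic acid or a longer alkyl chain, would move the number beyond the scatter on either core. The compounds shown also leave open whether replacing the 4-(trifluoromethyl)phenyl group or the 4-methylpiperidin-1-yl group would alter how the tert-butyl and trifluoromethyl pair compares.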